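The source may report more compounds than this note shows. Statements on the series, on what has been measured and on what is new or still open speak of the compounds shown alone.

Measured compounds: compound 1 `CC(=O)Nc1c(C(O)(C(F)(F)F)C(F)(F)F)ccc2ccccc12` with 95.5 nM, compound 2 `CCCC(=O)Nc1c(C(O)(C(F)(F)F)C(F)(F)F)ccc2ccccc12` with 708 nM, compound 3 `O=C(Nc1c(C(O)(C(F)(F)F)C(F)(F)F)ccc2ccccc12)C1CCC1` with 81.3 nM, all in a functional assay (Sus scrofa) with sulfonylurea receptors; K-ATP channels (Homo sapiens) as the target; on this read-out lower numbers stand for an effect already at smaller amounts and higher numbers for an effect only at larger amounts of compound.

Compound 3 gives the lowest number of the three in this assay; compound 1 sits within the scatter of it, as the step of a 1.2-fold lower number from compound 1 to compound 3 (0.07 log units; within the scatter) shows, while compound 2 lies clearly higher, an 8.7-fold lower number from compound 2 to compound 3 (0.94 log units; beyond the scatter). Compound 4 `Cc1cccc(C(=O)Nc2c(C(O)(C(F)(F)F)C(F)(F)F)ccc3ccccc23)c1` differs from compound 3 by 3-methylphenyl in place of cyclobutyl on a carbonyl carbon. Among the compounds with values here, no measured step swaps in an aromatic ring, so the bearing steps are indirect: a 7.4-fold higher number from compound 1 to compound 2 (0.87 log units; beyond the scatter) shows that a longer chain on the carbonyl carbon raised the number, whereas the compact cyclobutyl did not. A larger group here may therefore carry some cost, and a modest rise is expected, a 2.0-fold higher number from compound 3 to compound 4 (0.29 log units; within the scatter). Compound 4 is estimated at 160 nM, between 40 nM and 650 nM.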

Compound 4, half-maximal effective concentration: 52.5 nM
The estimate for compound 4 lay 3.0-fold (0.48 log units) above the measured number; measured number inside the range.
By their numbers in this assay, from the lowest: compounds 4, 3 and 1 (each within the scatter of the next); then compound 2.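

In this assay, 3-methylphenyl on the carbonyl carbon stays within the scatter of both smaller groups, a 1.5-fold lower number from compound 3 to compound 4 (0.19 log units; within the scatter) and a 1.8-fold lower number from compound 1 to compound 4 (0.26 log units; within the scatter), so a larger aromatic ring at this position does not raise the number, whereas the propyl of compound 2 stands clearly apart, a 13-fold lower number from compound 2 to compound 4 (1.13 log units; beyond the scatter). Group size alone therefore does not set the number among these four compounds, with compound 2 going against any simple trend of larger groups giving higher numbers. Nothing measured here explains this difference between propyl and 3-methylphenyl. Still open, as far as these compounds go, is how a plain phenyl, a pyridine ring, or an amine or carboxylic acid on the aromatic ring would compare.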